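The source may hold more compounds than are shown below. What is called first, only, known or untested is meant among the compounds shown, and "the series" means these compounds.

Measured in an assay on HEK293 cells for agonist activity at transient receptor potential cation channel subfamily M member 8 (Homo sapiens), read by fluorescence and calcium flux, with a stated time of 15 min; on this read-out higher numbers stand for an effect only at larger amounts of compound and lower numbers for an effect already at smaller amounts:
Compound 1 `Cc1ccc(OCC(=O)N(Cc2cccs2)CC(C)C)cc1` gives 900 nM.
Compound 2 `Cc1ccc(OCC(=O)N(Cc2cccs2)C2CCCCC2)cc1` gives 40000 nM.
Compound 3 `Cc1ccc(OCC(=O)N(Cc2cccs2)c2ccnn2C)cc1` gives 422 nM.

Compound 3 stands lowest of the three: the step of a 2.1-fold lower number from compound 1 to compound 3 (0.33 log units; beyond the scatter) is modest, while a 95-fold lower number from compound 2 to compound 3 (1.98 log units; beyond the scatter) is large. Compound 4 `Cc1ccc(OCC(=O)N(Cc2cccs2)c2ccccn2)cc1` differs from compound 3 in one place: pyridin-2-yl in place of 1-methyl-1H-pyrazol-5-yl on an amide-type nitrogen. Both the leaving and the entering group are aromatic rings. Going by the values given here, no measured step exchanges one aromatic ring for another; the two steps that bear on this position show only that an aromatic ring on this nitrogen gives lower numbers than isobutyl or cyclohexyl. Compound 4 is therefore expected to remain close to compound 3, with the step of a 1.2-fold higher number from compound 3 to compound 4 (0.07 log units; within the scatter) expected to be within or near the scatter. The estimate for compound 4 is 500 nM, in the range 150 nM to 1700 nM.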

Compound 4, half-maximal effective concentration: 200 nM
Compound 4: the middle estimate sits 2.5-fold (0.40 log units) above what was measured; the measured number falls inside the stated range.
By their numbers in this assay, from the lowest: compound 4; then compound 3; then compound 1; then compound 2.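

Swapping one aromatic ring for another on this amide-type nitrogen can shift the result beyond the scatter: the two rings have the same heavy-atom count, yet the swap gives a 2.1-fold lower number from compound 3 to compound 4 (0.32 log units; beyond the scatter). Pyridin-2-yl also widens the gap that aromatic rings already held over the two non-aromatic groups, with a 4.5-fold lower number from compound 1 to compound 4 (0.65 log units; beyond the scatter) and a 200-fold lower number from compound 2 to compound 4 (2.30 log units; beyond the scatter). No supporting data explain the difference between the two rings. As far as these compounds go, whether the ring nitrogen's place matters stays open, and pyridin-3-yl or plain phenyl on this nitrogen would test it.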